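The compounds below may be only part of what the source reports. "The series", "measured", "known", "first", "only" and "open" are said of these compounds alone.

Measured compounds:
compound 1 `N#C/C(=C\c1c(-c2ccccc2)[nH]c2ccccc12)C(=O)c1ccccc1` — "not determined" (no result reported)
compound 2 `O=C(/C(=C\c1c(-c2ccccc2)[nH]c2ccccc12)S(=O)(=O)c1ccccc1)c1ccccc1` — 9900 nM
compound 3 `COc1ccc(-c2[nH]c3ccc(OC)cc3c2/C=C(\C#N)S(=O)(=O)c2ccccc2)cc1` — 305 nM

In a functional assay on SR cells (Homo sapiens) for inhibition, read by sulforhodamine B assay, with a stated time of 48 h (on this read-out higher numbers stand for weaker inhibition of growth and lower numbers for stronger inhibition of growth), compound 3 gives 305 nM. This is the lowest of the two numbers available: compound 2 gives 9900 nM, a much higher number, and the gap between the two lies well beyond the scatter of repeated measurements. For compound 1 this assay returned no result, so it offers no comparison.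

The unmeasured compound 4 `COc1ccc(-c2[nH]c3ccccc3c2/C=C(\C#N)S(=O)(=O)c2ccccc2)cc1` differs from compound 3 in one place: hydrogen in place of methoxy on an aromatic carbon. The methoxy on the other six-membered ring of compound 4 is kept, as is the nitrile and the sulfonyl group that compound 3 also carries. Among the measured compounds shown here, no pair among the measured compounds shows this change on its own, so its size cannot be read from the data and has to be estimated.

Since the change is small and removes only a methoxy, the step is expected to be modest, likely toward a somewhat higher number, and it may not exceed the scatter; the step from compound 3 to compound 4 is estimated at a 2.0-fold higher number from compound 3 to compound 4 (0.29 log units; within the scatter). For compound 4 the expected value in this assay is 600 nM, with a range from 150 nM to 2500 nM.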

Compound 4, concentration for 50% growth inhibition: 350 nM
The estimate for compound 4 lay 1.7-fold (0.23 log units) above the measured number; measured number inside the range.
By their numbers in this assay, from the lowest: compounds 3 and 4 (each within the scatter of the next); then compound 2.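

In this assay, among the compounds shown here, the change of methoxy to hydrogen gives a 1.1-fold higher number from compound 3 to compound 4 (0.06 log units; within the scatter) and so provides the first comparison in this set between two compounds that differ in one place. At this position, on an aromatic carbon of a six-membered aromatic ring of carbon only that is part of a fused system of two rings, the methoxy can be removed with no change in the number beyond the scatter. The loss of its two heavy atoms and its hydrogen-bond acceptor therefore leaves no readable mark on this measure of growth inhibition, although no measurement at hand bears on why the two compounds read alike.

The compounds shown leave open whether a different group at this position, such as an amine or a carboxylic acid, would shift the number in this assay beyond the scatter, as hydrogen and methoxy do not. For the compounds shown here, they also leave open what the methoxy on the other six-membered ring contributes and how the nitrile compares on its own with a benzoyl group, as no pair here isolates either change.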